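A few compounds are considered here, and "the series" means these few. Any claim that something is new, unique, unknown or untested is made for them only; others in the source may bear on it.

Three compounds have so far been measured in an ADME assay on the whole organism for pharmacokinetics, with Homo sapiens as the target; on this read-out lower numbers stand for lower oral bioavailability and higher numbers for higher oral bioavailability:

compound 1, `O=S(=O)(Nc1ccccn1)c1ccc2nc(-c3ccccc3)c(-c3ccccc3)nc2c1`, giving 100%
compound 2, `O=S(=O)(Nc1ccc(Cl)cc1)c1ccc2nc(-c3ccccc3)c(-c3ccccc3)nc2c1`, giving 100%
compound 3, `O=S(=O)(Nc1ccccc1)c1ccc2nc(-c3ccccc3)c(-c3ccccc3)nc2c1`, giving 100%

Compound 1 stands level with compounds 2 and 3 in this assay; the gaps to both lie within the scatter. The three share one core and differ only in the group on the sulfonamide nitrogen. The step of no change at the digits printed from compound 1 to compound 2 (within the scatter), the step of no change at the digits printed from compound 1 to compound 3 (within the scatter) and the step of no change at the digits printed from compound 2 to compound 3 (within the scatter) all stayed flat within the scatter, so exchanging this group among pyridin-2-yl, phenyl and 4-chlorophenyl left oral bioavailability unchanged.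

Compound 4, `O=S(=O)(Nc1ccc(O)cc1)c1ccc2nc(-c3ccccc3)c(-c3ccccc3)nc2c1`, has not yet been measured. Its difference from compound 1 is 4-hydroxyphenyl in place of pyridin-2-yl on a sulfonamide nitrogen. Among the compounds with values here, the steps that bear on it are the two that also replace the group on the sulfonamide nitrogen of compound 1, both of which remained within the scatter. Within the data shown here, none of the measured compounds carries a hydroxyl group, so the data say nothing directly about that part of the change. Compound 4 is therefore expected to show a step of a number 5 percentage points lower from compound 1 to compound 4 (within the scatter), none beyond the scatter. The estimate for compound 4 is 95%, with a range from 75% to 100%.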

Compound 4, oral bioavailability: 93.9%
Estimate against measurement, compound 4: 1.1 percentage points above; low and high end bracket the measured number.
By their numbers in this assay, from the lowest: compounds 4, 1, 2 and 3 (each within the scatter of the next).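

In this assay the position on the sulfonamide nitrogen now accepts a ring carrying a hydrogen-bond donor, which none of the earlier groups had: the exchange of pyridin-2-yl for 4-hydroxyphenyl gave a number 6.1 percentage points lower from compound 1 to compound 4 (within the scatter) and so left oral bioavailability flat. Read on the benzene-type ring alone, hydroxy in place of hydrogen gave a number 6.1 percentage points lower from compound 3 to compound 4 (within the scatter) while hydroxy in place of chloro gave a number 6.1 percentage points lower from compound 2 to compound 4 (within the scatter) and neither change moved the read-out beyond the scatter, so the flat pattern now holds for all four groups shown, with no compound going against it. Nothing available on these compounds offers an explanation for this flat behaviour.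

All four groups shown are six-membered aromatic rings, so it remains open whether an amine or a carboxylic acid on that ring, or a saturated alkyl chain in place of the ring on the sulfonamide nitrogen, would stay equally flat. The shared core is the same throughout, so these compounds also say nothing about how a change there, such as a methoxy group on either outer phenyl ring, would affect oral bioavailability.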